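Trimethoxyphenyl series: dimethylamino for chloro on the pendant phenyl

The source may report more compounds than this note shows. Statements on the series, on what has been measured and on what is new or still open speak of the compounds shown alone.

Measured so far in a functional assay on HCT-116 cells (Homo sapiens) for inhibition, read by CCK-8 assay, with a stated time of 48 h; on this read-out lower numbers stand for stronger inhibition and higher numbers for weaker inhibition:
- compound 1, `COc1cc(-c2cc3nccc(-c4cc(OC)c(OC)c(OC)c4)n3n2)cc(OC)c1OC`: > 10000 nM
- compound 2, `COc1cc(-c2ccnc3cc(-c4cn(CO)c5ccccc45)nn23)cc(OC)c1OC`: 128 nM
- compound 3, `COc1cc(-c2ccnc3cc(-c4ccc(Cl)cc4)nn23)cc(OC)c1OC`: 3340 nM

The value of compound 1 is a limit of the assay, not a number; it sits at the limit of > 10000 nM in this assay, at which 1 of the 3 values shown sits. Among the two numbers, compound 3 gives the higher one, and compound 2 gives a lower number, a gap that lies beyond the scatter. Going by the values given here, no two measured compounds differ in a single place, so no measured step can be read from the data.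

Compound 4, `COc1cc(-c2ccnc3cc(-c4ccc(N(C)C)cc4)nn23)cc(OC)c1OC`, is the next entry and is not yet measured. It differs from compound 3 as follows: dimethylamino in place of chloro on an aromatic carbon. Both compounds keep the shared core and the trimethoxyphenyl group of compound 3.

Among the compounds with values here, with no measured step of this kind, the expectation for compound 4 rests on the spread of the two numbers alone. A change in this assay that reaches beyond the scatter is expected, toward a lower number, since compound 2 with its different pendant group gives 128 nM. Compound 4 is estimated at 1500 nM, within 400 nM to 6000 nM. The expected step from compound 3 to compound 4 is a 2.2-fold lower number from compound 3 to compound 4 (0.35 log units; beyond the scatter).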

Compound 4, half-maximal inhibitory concentration: 2050 nM
For compound 4 the middle estimate is 1.4-fold (0.14 log units) below the measured one; the measured number falls inside the stated range.
By their numbers in this assay, from the lowest: compound 2; then compounds 4 and 3 (each within the scatter of the next). At a limit, above all of these: compound 1.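

Going by these compounds alone, on the pendant phenyl, this assay now gives a first step in a single place, dimethylamino in place of chloro on an aromatic carbon para to a large group: a 1.6-fold lower number from compound 3 to compound 4 (0.21 log units; within the scatter). At this position, a chlorine atom and a dimethylamino group of three heavy atoms with one hydrogen-bond acceptor therefore cannot be told apart in this read-out. No measured property bears on this step, and it carries no stated cause.

On these data alone, whether a carboxylic acid, a primary amine or a longer chain at this position would reach beyond the scatter remains open. Within the data shown here, compound 2, at 128 nM, differs from compound 3 and compound 4 in the whole pendant group, so no single-place step to it can be read.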